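Series notes: from compound 1 to compound 4

This account rests on a few compounds, and the source may have more. Where it says the series, first, only, none or still open, it means among the compounds named here.

Measured so far in a functional assay on HEK293 cells for positive allosteric modulation of metabotropic glutamate receptor 5 (Homo sapiens), read by FLIPR and calcium flux; a lower number here means that less compound is needed, a higher number that more compound is needed for the effect:
- compound 1 `O=C(COCc1ccccc1)N1CCN(c2ccc(Cl)cc2Cl)CC1` gives 1000 nM
- compound 2 `O=C(COCc1ccccc1)N1CCN(c2ccc(F)cc2F)CC1` gives 300 nM
- compound 3 `O=C(COCc1ccccc1)N1CCN(c2cc(Cl)ccn2)CC1` gives 570 nM

Compound 1 holds the highest of the three numbers. Its nearest neighbour is compound 3, with a 1.8-fold lower number from compound 1 to compound 3 (0.24 log units; within the scatter); compound 2 lies furthest, with a 3.3-fold lower number from compound 1 to compound 2 (0.52 log units; beyond the scatter). Between the other two, a 1.9-fold higher number from compound 2 to compound 3 (0.28 log units; within the scatter) is also within the scatter. Every one of these steps alters only the group on the amine nitrogen in the ring; the benzyloxy side of the shared core is the same in all three measured compounds.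

Compound 4 `O=C(COCc1nccs1)N1CCN(c2ccc(Cl)cc2Cl)CC1` departs from compound 1 on that other side: 1,3-thiazol-2-yl in place of phenyl on a saturated chain carbon bound to an oxygen on a saturated carbon. Within the data shown here, no measured step touches this position, so the data give no direct guide to size or direction. The only scale on hand comes from the amine-side steps, of which the largest is a 3.3-fold lower number from compound 1 to compound 2 (0.52 log units; beyond the scatter), and that scale is modest. The working expectation for compound 4 is therefore a step of no change at the digits printed from compound 1 to compound 4 (within the scatter) that does not clear the scatter, carried with wide uncertainty. Compound 4 is estimated at 1000 nM, within a range from 350 nM to 3000 nM.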

Compound 4, half-maximal effective concentration: 10300 nM
The estimate for compound 4 lay 10-fold (1.01 log units) below the measured number, and the stated range ends below it.
By their numbers in this assay, from the lowest: compounds 2, 3 and 1 (each within the scatter of the next, the first and the last beyond it); then compound 4.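

In this assay the place on a saturated chain carbon bound to an oxygen on a saturated carbon proves sensitive: 1,3-thiazol-2-yl in place of phenyl gives a 10-fold higher number from compound 1 to compound 4 (1.01 log units; beyond the scatter) as its step, which outsizes a 3.3-fold lower number from compound 1 to compound 2 (0.52 log units; beyond the scatter) as the largest step on the amine side. The benzyloxy side of the shared core therefore matters at least as much to this read-out as the group on the amine nitrogen, and this one change, from a six-membered aromatic ring of carbon only to a five-membered aromatic ring with 2 hetero atoms, is poorly tolerated with 2,4-dichlorophenyl on the amine nitrogen. Nothing at hand accounts for the size of this step, so it stands as an observation only.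

Going by these compounds, it remains open whether the step belongs to 1,3-thiazol-2-yl specifically or to any departure from phenyl, a question that pyridin-2-yl, 1,3-oxazol-2-yl or 4-fluorophenyl at this place would help to settle. On these data alone, it is also open whether the same change costs as much with the 2,4-difluorophenyl of compound 2 or the 4-chloropyridin-2-yl of compound 3 on the amine nitrogen.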